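The source may report more compounds than this note shows. Statements on the series, on what has been measured and on what is new or still open speak of the compounds shown alone.

Compound 1 `COc1ccc(OC(=O)Nc2ccc([Se]C#N)cc2)cc1`: 19200 nM
Compound 2 `CCCOC(=O)Nc1ccc([Se]C#N)cc1`: 9100 nM
Compound 3 `CCOC(=O)Nc1ccc([Se][Se]c2ccc(NC(=O)OCC)cc2)cc1`: 16700 nM

Of the compounds shown here, three sharing a carbamate-bearing core have been measured in an ADME assay on 184B5 cells (Homo sapiens) for cytotoxicity, read by MTT assay, with a stated time of 72 h; a higher number here means a weaker inhibitor of growth, a lower number a stronger inhibitor of growth. Compound 2 gives 9100 nM and has the lowest number of the three. Compound 3, which gives 16700 nM, sits within the scatter of compound 2, so the two cannot be told apart. Compound 1 gives 19200 nM, and its gap to compound 2 lies beyond the scatter, so compound 2 does stand below compound 1 in this assay.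

The next compound, compound 4 `C=CCOC(=O)Nc1ccc([Se]C#N)cc1`, differs from compound 2 in a single respect: vinyl in place of ethyl on a saturated chain carbon bound to an oxygen next to a carbonyl group. For the measured compounds named here, no pair of measured compounds shows this same change, so its effect is not known from the data at hand. The change is small in size, keeps the count of heavy atoms, and adds only one double bond outside aromatic rings. On that basis the expected step is a 1.0-fold higher number from compound 2 to compound 4 (0.02 log units; within the scatter), none beyond the scatter. Compound 4 is therefore estimated to give about 9500 nM in this assay, with a range from 4500 nM to 20000 nM.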

Compound 4, concentration for total growth inhibition: 9800 nM
For compound 4 the middle estimate is 1.0-fold (0.01 log units) below the measured one; low and high end bracket the measured number.
By their numbers in this assay, from the lowest: compounds 2, 4, 3 and 1 (each within the scatter of the next, the first and the last beyond it).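

Putting vinyl in place of ethyl on a saturated chain carbon bound to an oxygen next to a carbonyl group gives a 1.1-fold higher number from compound 2 to compound 4 (0.03 log units; within the scatter) in this assay. For the compounds shown here, compound 2 and compound 4 are the first measured pair that differ in one place, and they show that propoxy to allyloxy, with its one double bond outside aromatic rings, leaves the two compounds indistinguishable at this position. No measurement is at hand that could explain this result.

The compounds shown leave open whether a longer chain, such as butyl or hexyl, would separate from propyl and allyl at this place. They also leave open how a chain ending in an amine or a carboxylic acid would read in this assay.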